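From compound 3 to compound 4: a new group on the amide chain

The source may report more compounds than this note shows. Statements on the series, on what has been measured and on what is new or still open speak of the compounds shown alone.

compound 1 `C[C@@H]1CN(c2sc(C(F)(F)F)nc2-c2nc3ccccc3[nH]2)CCN1C(=O)Cn1ccc(C(=O)O)n1`: 5570 nM
compound 2 `COC1CCN(CC(=O)N2CCN(c3sc(C(F)(F)F)nc3-c3nc4ccccc4[nH]3)C[C@H]2C)C1`: 3380 nM
compound 3 `C[C@@H]1CN(c2sc(C(F)(F)F)nc2-c2nc3ccccc3[nH]2)CCN1C(=O)CN1CCC(F)(F)CC1`: 2430 nM

In a functional assay on Venous blood for antagonist activity at C-X-C chemokine receptor type 3 (Homo sapiens), read by flow cytometry, with a stated time of 30 min, in the presence of a further agent that is not named here (on this read-out lower numbers stand for stronger inhibition and higher numbers for weaker inhibition), compound 3 shows the smallest number of the three, though a 1.4-fold lower number from compound 2 to compound 3 (0.14 log units; within the scatter) lies within the scatter and only a 2.3-fold lower number from compound 1 to compound 3 (0.36 log units; beyond the scatter) lies beyond it. Compound 4 `C[C@@H]1CN(c2sc(C(F)(F)F)nc2-c2nc3ccccc3[nH]2)CCN1C(=O)Cn1cnc2cccnc21` differs from compound 3 in one place: a group of 9 heavy atoms (6 carbon, 3 nitrogen; one five-membered aromatic ring with 2 hetero atoms, one six-membered aromatic ring with 1 hetero atom) in place of a group of 8 heavy atoms (5 carbon, 1 nitrogen, 2 fluorine; one six-membered non-aromatic ring with 1 hetero atom), on a saturated chain carbon bound to a carbonyl carbon. The measured steps that bear on this position are a 1.6-fold lower number from compound 1 to compound 2 (0.22 log units; within the scatter) and a 2.3-fold lower number from compound 1 to compound 3 (0.36 log units; beyond the scatter), both small, and they show that exchanging the group on this carbon has moved the number only modestly. A similar, modest rise is therefore expected here. Compound 4 is expected to give 3600 nM in this assay, with a range from 1300 nM to 10000 nM. The expected step is a 1.5-fold higher number from compound 3 to compound 4 (0.17 log units; within the scatter).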

Compound 4, half-maximal inhibitory concentration: 70 nM
Beside the measured number, compound 4's estimate is 51-fold (1.71 log units) above it, and the stated range ends above it.
By their numbers in this assay, from the lowest: compound 4; then compounds 3, 2 and 1 (each within the scatter of the next, the first and the last beyond it).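

In this assay, going by these compounds alone, this position proved far more responsive than the earlier compounds suggested: the group with two aromatic rings brings a 35-fold lower number from compound 3 to compound 4 (1.54 log units; beyond the scatter), and likewise a 48-fold lower number from compound 2 to compound 4 (1.68 log units; beyond the scatter) and an 80-fold lower number from compound 1 to compound 4 (1.90 log units; beyond the scatter). Among these four compounds, the group with two aromatic rings stands apart, while the three single-ring groups differ only modestly. Nothing given here accounts for this large change. Going by these compounds, whether both aromatic rings are needed stays open, as does what a phenyl group or a longer chain would give on this carbon.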